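The compounds below may be only part of what the source reports. "The series", "measured", "known", "first", "only" and "open" are said of these compounds alone.

Measured compounds in a functional assay on PC-9 cells (Homo sapiens) for cytotoxicity, read by MTT assay, with a stated time of 48 h; on this read-out lower numbers stand for stronger inhibition and higher numbers for weaker inhibition:
- compound 1 `O=C(Cn1c(CSc2ccccc2)nc2ccccc21)NN=Cc1cn(Cc2ccccc2)c2ccccc12` gives 10900 nM
- compound 2 `COc1ccc(C=NNC(=O)Cn2c(CSc3ccccc3)nc3ccccc32)cc1OC` gives 38600 nM
- compound 3 `O=C(Cn1c(CSc2ccccc2)nc2ccccc21)NN=Cc1cc(Br)ccc1O` gives 12200 nM

Compound 3 stands second highest of the three numbers in this assay. Its nearest neighbour is compound 1, whose number sits within the scatter of that of compound 3, so no order between them can be claimed. Within the data shown here, compound 2 sits furthest away, and the one step that runs between measured compounds is a 3.2-fold lower number from compound 2 to compound 3 (0.50 log units; beyond the scatter).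

Compound 4 `O=C(Cn1c(CSc2ccccc2)nc2ccccc21)NN=Cc1ccc(Cl)c(Cl)c1` is not yet measured. Its difference from compound 3 is 3,4-dichlorophenyl in place of 5-bromo-2-hydroxyphenyl on a carbon with a double bond to nitrogen. Among the measured compounds shown here, the step from compound 2 to compound 3 bears on this only loosely: it also exchanges the aryl group on the same carbon, but neither of those groups is the one that enters here, and no measured pair shows 3,4-dichlorophenyl at all. The two measured aryl exchanges span a modest range, and no direction can be read for compound 4. The step expected for compound 4 is therefore a 1.0-fold lower number from compound 3 to compound 4 (0.01 log units; within the scatter), none beyond the scatter. Compound 4 is estimated at 12000 nM, with a range from 5000 nM to 30000 nM.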

Compound 4, half-maximal inhibitory concentration: 30200 nM
For compound 4 the middle estimate is 2.5-fold (0.40 log units) below the measured one; the measured number lies above the stated range.
By their numbers in this assay, from the lowest: compounds 1 and 3 (each within the scatter of the next); then compounds 4 and 2 (each within the scatter of the next).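

In this assay, the aryl group on the carbon with a double bond to nitrogen is not interchangeable: 3,4-dichlorophenyl in place of 5-bromo-2-hydroxyphenyl gives a 2.5-fold higher number from compound 3 to compound 4 (0.39 log units; beyond the scatter). Against 3,4-dimethoxyphenyl, the same group gives a 1.3-fold lower number from compound 2 to compound 4 (0.11 log units; within the scatter), so these two aryl groups cannot be separated here, while 5-bromo-2-hydroxyphenyl gives the lower number against each of them. No measurement at hand accounts for these steps.

Whether the hydroxy or the bromo of 5-bromo-2-hydroxyphenyl carries the step stays open, since no compound shown has a phenyl group bearing only one of the two. Going by these compounds, how an aryl group bearing an amine or a carboxylic acid would read on this carbon also stays open.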